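The source may report more compounds than this note shows. Statements on the series, on what has been measured and on what is new or still open speak of the compounds shown alone.

Measured so far:
- compound 1, `C=CCOc1c(Cl)cc(N/C=N/OCC)cc1Cl`: in a physicochemical assay for lipophilicity, measured as octanol-water partition (on this read-out higher numbers stand for higher lipophilicity and lower numbers for lower lipophilicity), compound 1 gives 4.3
- compound 2, `C#CCc1c(Cl)cc(N/C=N/OCSC)cc1Cl`: in this assay compound 2 gives 3.6

Of the two numbers, compound 2 stands lowest, and compound 1 sits above it by a gap beyond the usual scatter. The unmeasured compound 3, `C#CCc1c(Cl)cc(N/C=N/Oc2ccc(C)cc2)cc1Cl`, is reached from compound 2 by one change: 4-methylphenyl in place of (methylsulfanyl)methyl on an oxygen. Going by the values given here, no such step has been measured here. A sizeable rise is expected, so the step from compound 2 to compound 3 is estimated at a number 1.20 log units higher from compound 2 to compound 3 (beyond the scatter). Compound 3 is therefore expected to give about 4.8, within a range from 4.3 to 5.4.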

Compound 3, partition coefficient: 4.8
Compound 3: middle estimate and measured number agree at the digits printed; measured number inside the range.
By their numbers in this assay, from the lowest: compound 2; then compound 1; then compound 3.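

Going by these compounds alone, compound 1 differs from compound 2 in more than one place, so this is the first pair to isolate a single change, on an oxygen whose other neighbour is a double-bonded nitrogen. In this assay, 4-methylphenyl in place of (methylsulfanyl)methyl gives a number 1.20 log units higher from compound 2 to compound 3 (beyond the scatter) and is a large step. Nothing measured here explains why.

The swap also removes the sulfur and adds a six-membered aromatic ring, so the compounds shown leave open which of these differences matters. A plain phenyl or a longer carbon chain on this oxygen would help separate them.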